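This account rests on a few compounds, and the source may have more. Where it says the series, first, only, none or still open, it means among the compounds named here.

Measured compounds:
compound 1 `CC(=O)c1cccc(-c2ccc(C(=O)N(Cc3cccc(OCCCCCC(=O)O)c3)C(C)C)cc2)c1` gives > 26000 nM in an ADME assay on HepG2 cells (Homo sapiens) for cytotoxicity, read by CellTiter-Glo and resazurin assay, with a stated time of 72 h; a higher number here means that more compound is needed for the effect, a lower number that less compound is needed;
compound 2 `CC(C)N(Cc1cccc(OCCCCCC(=O)O)c1)C(=O)c1ccc(-c2ccsc2)cc1` gives > 26000 nM in this assay;
compound 3 `CC(C)N(Cc1cccc(OCCCCCC(=O)O)c1)C(=O)c1ccc(-c2ccc(Cl)c(Cl)c2)cc1` gives > 26000 nM in this assay.

Each of these three values is a limit of the assay, not a number. Compound 3 therefore cannot be placed against the other two on the numbers shown, since all of them sit at the same limit (the limit of > 26000 nM in this assay, at which 3 of the 3 values shown sit). The step to the unmeasured compound 4 `CC(C)N(Cc1cccc(OCCCCCC(=O)O)c1)C(=O)c1ccc(-c2cccc([N+](=O)[O-])c2)cc1` is 3-nitrophenyl in place of 3,4-dichlorophenyl on an aromatic carbon. The measured steps that bear on this position of the shared core are a step that the two limits leave unreadable from compound 1 to compound 3, a step that the two limits leave unreadable from compound 2 to compound 3 and a step that the two limits leave unreadable from compound 1 to compound 2; none of them has a readable size, as both ends of each step are limits. Nothing in the measured steps points to a direction for compound 4 in this assay, so no step beyond the scatter is expected, and the estimated step that the limit leaves unreadable from compound 3 to compound 4 is most likely unreadable in the same way. Compound 4 is expected to give 50000 nM, with a range from 26000 nM to 200000 nM, most probably reported again only as a limit.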

Compound 4, half-maximal effective concentration: > 26000 nM
Compound 4: no number, only a limit; the forecaster's own chance of this, stated with the estimate: 90%; the middle value is on the limit's open side.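

In this assay compound 4 gives > 26000 nM as a limit and not a number. For the compounds shown here, no step among compound 1, compound 2, compound 3 and compound 4 can be read, as all four stand at one limit: the limit of > 26000 nM in this assay, at which 4 of the 4 values shown sit. The compounds shown leave open whether any of them differs from the others in this assay at all.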